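The source may hold more compounds than are shown below. What is called first, only, known or untested is meant among the compounds shown, and "the series" means these compounds.

Compound 1 `O=C(Cc1ccc(F)cc1)NS(=O)(=O)c1ccc(Cl)cc1`: 6.36 ug/mL
Compound 2 `O=C(Cc1ccc(F)cc1)NS(=O)(=O)c1ccccc1`: 9.07 ug/mL

In a functional assay on B16-F10 cells (Mus musculus) for antiproliferative activity, read by MTT assay, with a stated time of 48 h (on this read-out lower numbers stand for stronger inhibition and higher numbers for weaker inhibition), compound 1 gives 6.36 ug/mL and compound 2 gives 9.07 ug/mL. Compound 2 has the higher of the two numbers, yet the step of a 1.4-fold higher number from compound 1 to compound 2 (0.15 log units; within the scatter) is too small to rank them. Compound 3 `Cc1ccc(S(=O)(=O)NC(=O)Cc2ccc(F)cc2)cc1` is not yet measured; it differs from compound 2 by methyl in place of hydrogen on an aromatic carbon. For the measured compounds named here, the only measured step that bears on this, a 1.4-fold higher number from compound 1 to compound 2 (0.15 log units; within the scatter), exchanged a group on an aromatic carbon and stayed within the scatter. A step beyond the scatter is therefore not expected, and the expected step is a 1.1-fold lower number from compound 2 to compound 3 (0.05 log units; within the scatter). For compound 3 the estimate is 8 ug/mL, with a range from 4 ug/mL to 16 ug/mL.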

Compound 3, half-maximal inhibitory concentration: 9.94 ug/mL
The estimate for compound 3 lay 1.2-fold (0.09 log units) below the measured number; the measured number falls inside the stated range.
By their numbers in this assay, from the lowest: compounds 1, 2 and 3 (each within the scatter of the next).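

Across hydrogen, chloro and methyl on this aromatic carbon in this assay, the numbers stay close: the change gives a 1.1-fold higher number from compound 2 to compound 3 (0.04 log units; within the scatter) and, set against chloro, a 1.6-fold higher number from compound 1 to compound 3 (0.19 log units; within the scatter), both small enough that no order can be drawn. So adding a methyl carbon at this position, or exchanging chloro for methyl, produces no readable shift. No measurement at hand explains why these numbers stay so close. Still open, from the compounds shown here alone, is whether an amine, a carboxylic acid or a longer chain at this position would move the number beyond the scatter.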